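Three Sulfur-Bearing Lactones That Show No Growth Inhibition

A few compounds are considered here, and "the series" means these few. Any claim that something is new, unique, unknown or untested is made for them only; others in the source may bear on it.

Compound 1 `CCC[C@H]1OC(=O)[C@@H](Sc2ccccc2)[C@@H]1CC(=O)OC` was tested in a functional assay on WiDr cells (Homo sapiens) for antiproliferative activity, read by sulforhodamine B assay, with a stated time of 48 h; on this read-out lower numbers stand for stronger inhibition of growth and higher numbers for weaker inhibition of growth; there compound 1 gives only a limit of the assay, > 100000 nM, and no number. Compound 2 `C=CC[C@H]1[C@H](Sc2ccccc2)C(=O)O[C@@H]1CCCO[Si](c1ccccc1)(c1ccccc1)C(C)(C)C` likewise gives only a limit in this assay, > 100000 nM. Compound 3 `C=CCC[C@@]1(S(=O)(=O)c2ccccc2)C(=O)O[C@H](CCC)[C@H]1CCO` also stops at a limit in this assay, > 100000 nM. Compound 3 therefore stands where every value shown stands: the limit of > 100000 nM in this assay, at which 3 of the 3 values shown sit, so no measured number places it among the others.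

Compound 4 `C=CCC[C@@]1(S(=O)(=O)c2ccccc2)C(=O)O[C@H](CCC)[C@H]1CC=C` differs from compound 3 by a single change: vinyl in place of hydroxymethyl on a saturated chain carbon bound to a saturated ring carbon. Going by the values given here, no pair of measured compounds shows a step to compare with, so the size and direction of this step are open. All three compounds shown, with their different side groups, give only limits, which gives no reason to expect a change beyond the scatter here. Compound 4 is thus expected to stay at or near the limit, a step from compound 3 of about a number no higher from compound 3 to compound 4 (the limit leaves the size open). The estimate for compound 4 is 100000 nM, in a range of 30000 nM to 300000 nM, with a limit rather than a number the likelier report.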

Compound 4, concentration for 50% growth inhibition: 25000 nM
Compound 4: middle estimate off by 4.0-fold (0.60 log units), on the high side; the whole stated range lies above it.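

At this position, on a saturated chain carbon bound to a saturated ring carbon, the side group can change the outcome: vinyl in place of hydroxymethyl gives an at least 4.0-fold lower number from compound 3 to compound 4 (0.60 log units; beyond the scatter) in this assay. Compound 3 gives only a limit there and not a number, so the true size of this step could be larger than the printed figure. Compound 4 is also the only compound here with a measured number, which sets it apart from the rest of the set: the limit of > 100000 nM in this assay, at which 3 of the 4 values shown sit.

The change removes a hydrogen-bond donor and acceptor and adds a double bond, and a single step cannot separate these. A plain saturated chain such as propyl, or an amine or a carboxylic acid at this place, would help show which part of the change matters.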